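The compounds below may be only part of what the source reports. "The series", "measured", "known", "first", "only" and "open" are said of these compounds alone.

Measured so far:

Compound 1, `O=C(CCC1=CCN(CCCc2ccc(Br)cc2)C1=O)NO`, in a functional assay on HCT-15 cells (Homo sapiens) for inhibition, read by sulforhodamine B assay (on this read-out higher numbers stand for weaker inhibition of growth and lower numbers for stronger inhibition of growth), compound 1 gives 5100 nM.
Compound 2, `O=C(CCC1=CCN(Cc2ccc(F)cc2)C1=O)NO`, in this assay compound 2 gives 4070 nM.
Compound 3, `Cc1ccc(CCCCN2CC=C(CCC(=O)NO)C2=O)cc1`, in this assay compound 3 gives 8540 nM.

All three share the same core and differ only in the chain that joins the core to a six-membered aromatic ring of carbon only and in the group on that ring. Compound 2 has the lowest of the three numbers. Its number and that of compound 1 lie within the scatter of each other, so no order between them can be read; compound 3 stands beyond the scatter, with a higher number than compound 2.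

Compound 4, `CC(C)(C)c1ccc(CN2CC=C(CCC(=O)NO)C2=O)cc1`, has not yet been measured. It differs from compound 2 in one place: tert-butyl in place of fluoro on an aromatic carbon. Among the compounds with values here, nothing among the measured compounds shows what such a swap does, so the step in this assay from compound 2 to compound 4 is expected to be small, within the scatter, in either direction. The estimate for compound 4 is 3500 nM, with a range from 1200 nM to 10000 nM, which means an expected step of a 1.2-fold lower number from compound 2 to compound 4 (0.07 log units; within the scatter).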

Compound 4, concentration for 50% growth inhibition: 570 nM
For compound 4 the middle estimate is 6.1-fold (0.79 log units) above the measured one; the measured number lies below the stated range.
By their numbers in this assay, from the lowest: compound 4; then compounds 2, 1 and 3 (each within the scatter of the next, the first and the last beyond it).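

Placing tert-butyl in place of fluoro on this aromatic carbon gives a 7.1-fold lower number from compound 2 to compound 4 (0.85 log units; beyond the scatter) in this assay, so the group at this position can clearly change the read-out. The earlier compounds shown here could not show this, since they differ from one another in both the chain and the ring group, and so no single change could be read from them. No measurement here explains the step, which records the effect of the swap but not its cause.

This single pair cannot show whether other groups at this position, such as methoxy, an amine or a carboxylic acid, would shift the number in the same direction. It also leaves open whether tert-butyl would have a similar effect on a compound with a longer chain.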